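Toward a prenyl ether in a cyclic sulfonate series

The source may report more compounds than this note shows. Statements on the series, on what has been measured and on what is new or still open speak of the compounds shown alone.

Measured compounds:
Compound 1 `CC1(Cc2ccccc2)OS(=O)(=O)C=C1OCc1ccccc1` gives 68000 nM in an ADME assay on HEL cells (Homo sapiens) for cytotoxicity, with a stated time of 3 days; a higher number here means that more compound is tolerated, a lower number that less compound is tolerated.
Compound 2 `CCC1(Cc2ccccc2)OS(=O)(=O)C=C1OCc1ccc(C)cc1` gives 41500 nM in this assay.

Going by the values given here, only these two numbers exist so far, and they sit within the usual scatter of one another, so nothing separates compound 2 from compound 1 in this assay; compound 2 simply stands where the whole pair stands, with no step between them that can be called real. No single-point change between measured compounds is available to lean on.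

Compound 3 `CCC1(Cc2ccccc2)OS(=O)(=O)C=C1OCC=C(C)C` has not been measured. It differs from compound 2 in one place: 2-methylprop-1-en-1-yl in place of 4-methylphenyl on a saturated chain carbon bound to an oxygen on an unsaturated carbon. The shared core, including the benzyl group on the saturated ring carbon, is kept; only the group on the ether oxygen changes, with the six-membered aromatic ring giving way to a short open chain carrying one double bond.

Among the compounds with values here, with no measured step of this kind to draw on, the expectation rests on the two numbers alone. Compound 3 is expected to stay within the scatter of compound 2, and any step a 1.2-fold higher number from compound 2 to compound 3 (0.08 log units; within the scatter) is estimated to be small. Compound 3 is estimated at 50000 nM, in a range from 20000 nM to 120000 nM.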

Compound 3, half-maximal cytotoxic concentration: 112000 nM
The estimate for compound 3 lay 2.2-fold (0.35 log units) below the measured number; measured number inside the range.
By their numbers in this assay, from the lowest: compounds 2, 1 and 3 (each within the scatter of the next, the first and the last beyond it).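

Going by these compounds alone, exchanging 4-methylphenyl for 2-methylprop-1-en-1-yl on a saturated chain carbon bound to an oxygen on an unsaturated carbon gives the first step that lies beyond the scatter: in this assay there is a 2.7-fold higher number from compound 2 to compound 3 (0.43 log units; beyond the scatter). This shows that the group at this place can shift the tolerated concentration even with the rest of compound 2 kept, a point that the two earlier compounds, which gave no readable step, could not show. It also shows that the six-membered aromatic ring is not needed at this place for a high number, although the step is modest and rests on a single pair, and nothing at hand explains why the number moves.

Within the data shown here, the single pair leaves open whether the loss of the ring, the double bond or the smaller heavy-atom count carries the step, as all three change together. Also open, as far as these compounds go, is whether a saturated 3-methylbutyl chain, a longer prenyl-type chain or a chain ending in an amine at the same place would give a number like that of compound 3.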